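From furan-2-yl to naphthalen-1-yl on a shared core

A few compounds are considered here, and "the series" means these few. Any claim that something is new, unique, unknown or untested is made for them only; others in the source may bear on it.

Values in a functional assay for inhibition, with Homo sapiens as the target; on this read-out lower numbers stand for tighter binding and higher numbers for weaker binding:
Compound 1 `N#Cc1ccccc1C1OCC(C/C=C\CCC(=O)O)C(c2cccnc2)O1`: 245 nM
Compound 2 `O=C(O)CC/C=C\CC1COC(c2ccsc2)OC1c1cccnc1`: 1580 nM
Compound 3 `O=C(O)CC/C=C\CC1COC(c2ccco2)OC1c1cccnc1`: 1260 nM

With 1260 nM, compound 3 sits with compound 2 at the high end of these numbers, and the two lie within the scatter of each other: a 1.3-fold lower number from compound 2 to compound 3 (0.10 log units; within the scatter). Compound 1 has the lowest number of the three, which means the tightest binding.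

Compound 4 `O=C(O)CC/C=C\CC1COC(c2cccc3ccccc23)OC1c1cccnc1` keeps the shared core, but naphthalen-1-yl takes the place of furan-2-yl on the saturated ring carbon between two ring oxygen atoms: naphthalen-1-yl in place of furan-2-yl on a saturated ring carbon.

Among the measured compounds shown here, no measured step makes this exact swap. The closest guides are the two steps away from 2-cyanophenyl: a 5.1-fold higher number from compound 1 to compound 3 (0.71 log units; beyond the scatter) and a 6.4-fold higher number from compound 1 to compound 2 (0.81 log units; beyond the scatter). Both are modest and beyond the scatter. Like compound 1, compound 4 carries a six-membered aromatic ring at this place, which points toward the lower value of compound 1 at 245 nM. Naphthalen-1-yl has no nitrile, however, and no compound here shows what that omission does, so only part of that gap is expected to be recovered.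

A modest move to a lower number is expected: a 2.8-fold lower number from compound 3 to compound 4 (0.45 log units; beyond the scatter). For compound 4 the estimated value is 450 nM, with an expected range from 130 nM to 1500 nM.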

Compound 4, dissociation constant: 631 nM
For compound 4 the middle estimate is 1.4-fold (0.15 log units) below the measured one, and the stated range covers the measured number.
By their numbers in this assay, from the lowest: compound 1; then compounds 4, 3 and 2 (each within the scatter of the next, the first and the last beyond it).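

In this assay, the saturated ring carbon between two ring oxygen atoms accepts naphthalen-1-yl, with 10 heavy atoms against the 5 of furan-2-yl, and the change stays within the scatter (a 2.0-fold lower number from compound 3 to compound 4 (0.30 log units; within the scatter)). Against thiophen-3-yl the same group gives a modest step beyond the scatter (a 2.5-fold lower number from compound 2 to compound 4 (0.40 log units; beyond the scatter)), while 2-cyanophenyl still keeps a modest edge that is also beyond the scatter (a 2.6-fold higher number from compound 1 to compound 4 (0.41 log units; beyond the scatter)), so two fused six-membered aromatic rings of carbon only do not reach the number of compound 1. Nothing measured here explains why these groups differ.

As far as these compounds go, it remains open how an unsubstituted phenyl group would compare at this position, which would help separate the contribution of the nitrile from that of the ring carrying it, and whether naphthalen-2-yl would behave like naphthalen-1-yl. From the compounds shown here alone, the pyridin-3-yl and 5-carboxypent-2-en-1-yl groups stay the same in all four compounds, so it is also open whether these differences would hold with another group at those places, such as an amide in place of the carboxylic acid.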